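Benzyl groups on the sulfanyl sulfur and cytotoxicity

This account rests on a few compounds, and the source may have more. Where it says the series, first, only, none or still open, it means among the compounds named here.

Working notes on the series. Compound 1 `Cn1cc(SCc2nnc(S)n2-c2c(Cl)cccc2Cl)c2ccccc21` in a toxicity assay on HEK-293T cells (Homo sapiens) for cytotoxicity, read by CCK-8 assay, with a stated time of 48 h (on this read-out higher numbers stand for lower toxicity in this test and lower numbers for higher toxicity in this test), gives > 100000 nM, a limit of the assay and not a number. Compound 2 `Cn1cc(SCc2nnc(SCc3ccccc3Cl)n2-c2c(Cl)cccc2Cl)c2ccccc21` gives 49600 nM in this assay. Among the measured compounds shown here, the only measured step, an at least 2.0-fold lower number from compound 1 to compound 2 (0.30 log units; that floor lies within the scatter), starts from the limit of > 100000 nM in this assay, at which 1 of the 2 values shown sits. Compound 3 `Cn1cc(SCc2nnc(SCc3cccc(Cl)c3Cl)n2-c2c(Cl)cccc2Cl)c2ccccc21` differs from compound 1 by 2,3-dichlorobenzyl in place of hydrogen on a sulfur, a change of the same kind as that to compound 2. A downward step at least as large is therefore expected, in the range of the measured one. Compound 3 is expected to give 45000 nM (range 20000 nM to 100000 nM) in this assay, a step of an at least 2.2-fold lower number from compound 1 to compound 3 (0.34 log units; beyond the scatter).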

Compound 3, half-maximal cytotoxic concentration: > 100000 nM
Compound 3: only a limit was reported; the forecaster's own chance of this, stated with the estimate: 20%; at least 2.2-fold (0.34 log units) between middle value and limit.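

In this assay compound 3 gives > 100000 nM, a limit of the assay, so 2,3-dichlorobenzyl on this sulfur does not bring the number into the readable range as 2-chlorobenzyl does. The added chloro on the aromatic carbon gives an at least 2.0-fold higher number from compound 2 to compound 3 (0.30 log units; that floor lies within the scatter), a floor within the scatter, so no order between the two benzyl groups is established. The step between the two limit compounds cannot be read: the limit of > 100000 nM in this assay, at which 2 of the 3 values shown sit.

Open, going by these compounds, is how far compound 1 and compound 3 lie beyond the limit. Also open, on these data alone, is whether an amine, a carboxylic acid or a longer chain on this sulfur gives a readable number.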